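Swapping the Ring on the Nitrogen of Compound 2

The source may report more compounds than this note shows. Statements on the series, on what has been measured and on what is new or still open speak of the compounds shown alone.

Compound 2 `O=C(Cc1nn(C2CCNC2)c(=O)c2ccccc12)Nc1ccc(OC(F)(F)F)c(Cl)c1` carries a pyrrolidin-3-yl group on an aromatic nitrogen of the shared core. Going by the values given here, in a functional assay on CHO cells for antagonist activity at sphingosine 1-phosphate receptor 2 (Homo sapiens), read by calcium flux (on this read-out lower numbers stand for stronger inhibition and higher numbers for weaker inhibition), compound 2 gives 94 nM, the lowest of the two numbers measured so far. Among the compounds with values here, its only neighbour, compound 1 `CCn1nc(CC(=O)Nc2ccc(OC(F)(F)F)c(Cl)c2)c2ccccc2c1=O`, has an ethyl group in the same place and gives 199 nM. Compound 3 `O=C(Cc1nn(C2CC2)c(=O)c2ccccc12)Nc1ccc(OC(F)(F)F)c(Cl)c1` has not been measured yet; it differs from compound 2 in one place: cyclopropyl in place of pyrrolidin-3-yl on an aromatic nitrogen. Within the data shown here, the one measured step that bears on this change is a 2.1-fold lower number from compound 1 to compound 2 (0.33 log units; beyond the scatter), where a ring with one hydrogen-bond donor and one acceptor replaced a plain ethyl. Going the other way, to a cyclopropyl with no donor or acceptor, is expected to undo part of that gain, so a modest rise is expected, a 1.8-fold higher number from compound 2 to compound 3 (0.26 log units; within the scatter). Compound 3 is therefore estimated at 170 nM, with a range from 70 nM to 400 nM.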

Compound 3, half-maximal inhibitory concentration in the sphingosine 1-phosphate receptor 2 assay: 218 nM
For compound 3 the middle estimate is 1.3-fold (0.11 log units) below the measured one, within the range that was stated.
By their numbers in the sphingosine 1-phosphate receptor 2 assay, from the lowest: compound 2; then compounds 1 and 3 (each within the scatter of the next).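

In the sphingosine 1-phosphate receptor 2 assay, cyclopropyl in place of pyrrolidin-3-yl gives a 2.3-fold higher number from compound 2 to compound 3 (0.37 log units; beyond the scatter), so the earlier gain does not survive this swap. Cyclopropyl in place of ethyl gives a 1.1-fold higher number from compound 1 to compound 3 (0.04 log units; within the scatter), which means these two groups cannot be told apart here, and having a ring on this nitrogen is not enough to match pyrrolidin-3-yl. In a physicochemical assay for lipophilicity, at pH 7.4 (a lower number here means a more polar compound, a higher number a more lipophilic compound), compound 2 gives 3.03 and compound 3 gives 5.43. The same swap also makes the compound far more lipophilic in the physicochemical assay: the measured distribution coefficient of compound 2, 3.03, and of compound 3, 5.43, a number 2.40 log units higher (beyond the scatter)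

As far as these compounds go, whether the lower number of compound 2 in the sphingosine 1-phosphate receptor 2 assay follows the nitrogen of the pyrrolidin-3-yl group itself, or simply its lower distribution coefficient, stays open. A tetrahydrofuran-3-yl group, with an oxygen where that nitrogen stands, or an open-chain aminoethyl group could help separate the two.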